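Methoxy addition on the aryl rings of the bisbenzylidene core

This account rests on a few compounds, and the source may have more. Where it says the series, first, only, none or still open, it means among the compounds named here.

Compound 1 `COc1ccccc1/C=C1\CCC/C(=C\c2cccc(OC)c2OC)C1=O` is tested in a functional assay on SW-620 cells (Homo sapiens) for cytotoxicity, read by MTT assay, with a stated time of 72 h; a higher number here means a weaker inhibitor, a lower number a stronger inhibitor. For compound 1 the read-out is a limit, > 20000 nM. Compound 2 `COc1ccc(/C=C2\CCC/C(=C\c3cccc(OC)c3OC)C2=O)c(OC)c1` carries a methoxy in place of hydrogen on an aromatic carbon, placed meta to a methoxy group and para to a large group (methoxy in place of hydrogen on an aromatic carbon). For compound 2 the read-out is likewise a limit, > 20000 nM. The step that the two limits leave unreadable from compound 1 to compound 2 therefore cannot be read, because the limit of > 20000 nM in this assay, at which 2 of the 3 values shown sit, caps both values. Compound 3 `COc1ccc(/C=C2\CCC/C(=C\c3ccc(OC)c(OC)c3)C2=O)cc1` has the same atoms as compound 1 joined differently; the difference between the two cores is not broken down here. In this assay, going by the values given here, compound 3 gives 6600 nM, the only number among the three. Compound 4 `COc1ccc(/C=C2\CCC/C(=C\c3ccc(OC)c(OC)c3)C2=O)cc1OC` differs from compound 3 by a methoxy in place of hydrogen on an aromatic carbon, ortho to a methoxy group and meta to a large group (methoxy in place of hydrogen on an aromatic carbon), the same kind of change as from compound 1 to compound 2 but at a different place. Since that earlier step is unreadable, the step of a 1.2-fold lower number from compound 3 to compound 4 (0.08 log units; within the scatter) is expected to stay within the usual scatter of compound 3 at 6600 nM. Compound 4 is expected to give about 5500 nM, between 1800 nM and 20000 nM.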

Compound 4, half-maximal inhibitory concentration: 4500 nM
For compound 4 the middle estimate is 1.2-fold (0.09 log units) above the measured one; the measured number falls inside the stated range.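

In this assay, a methoxy in place of hydrogen on an aromatic carbon of the core of compound 3 gives a 1.5-fold lower number from compound 3 to compound 4 (0.17 log units; within the scatter), so at this place, ortho to a methoxy group and meta to a large group, the change stays within the scatter. The same kind of change on the core of compound 1 cannot be read, because both compounds of that pair sit at a limit: the limit of > 20000 nM in this assay, at which 2 of the 4 values shown sit. The series thus holds one readable instance of this change, at one place on one core, and it shows neither that the result carries over to the core of compound 1 nor that it fails to; the two changes also sit at different places.

All compounds shown carry only methoxy groups on their aryl rings. Going by these compounds, what an amine, a carboxylic acid or a longer chain would give at this place on the core of compound 3 stays open.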